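The source may hold more compounds than are shown below. What is called first, only, known or untested is meant among the compounds shown, and "the series" means these compounds.

Measured in an ADME assay on MT4 cells (Homo sapiens) for cytotoxicity, read by MTT assay, with a stated time of 96 h; a higher number here means that more compound is tolerated, a lower number that less compound is tolerated:
- compound 1 `Brc1ccc(NCc2cn(-c3ccccc3)nc2-c2ccccc2)cc1` gives > 100000 nM (a limit)
- compound 2 `Cc1ccc(NCc2cn(-c3ccccc3)nc2-c2ccc(C)cc2)cc1` gives > 100000 nM (a limit)
- compound 3 `Cc1ccc(-c2nn(-c3ccccc3)cc2CNc2ccc(Br)cc2)cc1` gives > 100000 nM (a limit)

Compound 3 reads > 100000 nM as a limit and not a number, and the other two compounds share that standing: the limit of > 100000 nM in this assay, at which 3 of the 3 values shown sit, applies to the whole set. Compound 4 `Cc1ccc(-c2nn(-c3ccccc3)cc2CNc2ccccc2)cc1` is compound 3 with hydrogen in place of bromo on an aromatic carbon, para to a large group, counted as hydrogen in place of bromo on an aromatic carbon in full.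

Within the data shown here, two measured steps bear on this change: a step that the two limits leave unreadable from compound 1 to compound 3 and a step that the two limits leave unreadable from compound 2 to compound 3 are the ones available. Neither gives a size to carry over, although the second also concerns the bromo group. In this assay no step beyond the scatter is therefore expected, and no direction can be given. For compound 4 the estimated value is 100000 nM in a range of 50000 nM to 100000 nM as expected from the limit shared by the set. The expected change is a number no higher from compound 3 to compound 4 (the limit leaves the size open) on this estimate.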

Compound 4, half-maximal cytotoxic concentration: > 100000 nM
Compound 4 ended at the assay's limit (the forecaster's own chance of this, stated with the estimate: 85%); the middle value lies on the limit itself.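

In this assay compound 4 gives > 100000 nM, a limit. The steps to compound 4 from compound 2 and compound 3 cannot be read: the limit of > 100000 nM in this assay, at which 4 of the 4 values shown sit.

The compounds shown leave open whether bromo, methyl or hydrogen at these aromatic positions changes the half-maximal cytotoxic concentration at all.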